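Compound 3: a hydroxy-bearing chain on the series

The source may hold more compounds than are shown below. What is called first, only, known or untested is meant among the compounds shown, and "the series" means these compounds.

Measured in a functional assay (plasma) with Oryctolagus cuniculus as the target; on this read-out lower numbers stand for stronger inhibition and higher numbers for weaker inhibition:
- compound 1 `CCCC(CC(=O)N1CCC(Cn2c(C)nc3cnccc32)CC1)c1ccccc1`: 11 nM
- compound 2 `Cc1nc2cnccc2n1CC1CCN(C(=O)CCc2ccccc2)CC1`: 60 nM

Of these two, compound 2 has the higher number, 60 nM, and so the weaker inhibition. The next compound to be measured is compound 3 `Cc1nc2cnccc2n1CC1CCN(C(=O)CC(C)(O)c2ccccc2)CC1`. It differs from compound 2 as follows: 1-hydroxy-1-phenylethyl in place of benzyl on a saturated chain carbon bound to a carbonyl carbon. In words, this is 1-hydroxy-1-phenylethyl in place of benzyl on a saturated chain carbon bound to a carbonyl carbon.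

For the measured compounds named here, only one measured step bears on this change: a 5.5-fold higher number from compound 1 to compound 2 (0.74 log units; beyond the scatter). That step is modest and beyond the scatter, with hydrogen in place of propyl on a saturated chain carbon bound to an aromatic carbon and a saturated chain carbon. Read in reverse, it links the added propyl to the lower number, so a modest move towards a lower number in this assay is expected here. Going by the values given here, no measured compound carries a hydroxy group, and a single step is thin support, so the expectation stays loose. The estimated change is a 2.0-fold lower number from compound 2 to compound 3 (0.30 log units; within the scatter). For compound 3 the estimated value is 30 nM, with an expected range of 8 nM to 110 nM.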

Compound 3, half-maximal inhibitory concentration: 6.9 nM
Compound 3: middle estimate off by 4.3-fold (0.64 log units), on the high side, and the stated range ends above it.
By their numbers in this assay, from the lowest: compounds 3 and 1 (each within the scatter of the next); then compound 2.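

In this assay, the saturated chain carbon bound to a carbonyl carbon accepts a hydroxy-bearing group, the first in the series with a hydrogen-bond donor: 1-hydroxy-1-phenylethyl in place of benzyl gives an 8.7-fold lower number from compound 2 to compound 3 (0.94 log units; beyond the scatter), a step beyond the scatter. Compared with the propyl-bearing group of compound 1, 1-hydroxy-1-phenylethyl in place of 1-phenylbutyl gives a 1.6-fold lower number from compound 1 to compound 3 (0.20 log units; within the scatter), so at this position two quite different substituents, one with a hydroxy group and one with a hydrocarbon chain, both stand apart from compound 2 and cannot be told apart from each other. No supporting data bear on why the hydroxy-bearing group gives this result.

The 1-hydroxy-1-phenylethyl group differs from benzyl by both a hydroxy group and a methyl group, and the compounds shown do not separate the share of each in the step. Also open, on these data alone, is whether a methoxy group or an amine in place of the hydroxy group, or a longer chain in place of the methyl group, would keep the number of compound 3 in this assay.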